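Working notes on cytotoxicity for compounds 1 to 3

The source may report more compounds than this note shows. Statements on the series, on what has been measured and on what is new or still open speak of the compounds shown alone.

Going by the values given here, compound 1 `Cc1cn(C2CCN(Cc3cccc(Oc4cc(Cl)cc(Cl)c4)c3)CC2)c(=O)[nH]c1=O` is the only member of the set with a number in an ADME assay on MRC5 cells (Homo sapiens) for cytotoxicity, read by fluorescence and resazurin assay, with a stated time of 3 days (on this read-out lower numbers stand for stronger inhibition and higher numbers for weaker inhibition), where compound 1 gives 6730 nM. Among the compounds with values here, compound 2 `Cc1cn(C2CCN(Cc3cc(Oc4cc(Cl)cc(Cl)c4)ccn3)CC2)c(=O)[nH]c1=O` was also run in this assay, but for compound 2 the entry reads "not determined" (no result reported), so compound 1 stands alone and no comparison between measured compounds can be drawn. Compound 3 `Cc1cn(C2CCN(Cc3cccc(Oc4cccc(C(F)(F)F)c4)c3)CC2)c(=O)[nH]c1=O` differs from compound 1 by 3-(trifluoromethyl)phenyl in place of 3,5-dichlorophenyl on an oxygen on an aromatic ring. Within the data shown here, nothing among the measured compounds shows how this change acts in this assay, so the expectation rests on compound 1 alone: the expected shift in this assay is a 1.2-fold higher number from compound 1 to compound 3 (0.08 log units; within the scatter), which lies within the usual scatter and carries no clear direction. Compound 3 is accordingly estimated to give about 8000 nM in this assay, with a range from 3000 nM to 22000 nM. A limit instead of a number remains a real possibility for compound 3 in this assay.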

Compound 3, half-maximal inhibitory concentration: 12400 nM
Compound 3: the middle estimate sits 1.6-fold (0.19 log units) below what was measured; low and high end bracket the measured number.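

Going by these compounds alone, the first readable step at this place, on an oxygen on an aromatic ring, is in this assay a 1.8-fold higher number from compound 1 to compound 3 (0.27 log units; within the scatter). Putting 3-(trifluoromethyl)phenyl in place of 3,5-dichlorophenyl therefore gives two compounds that this read-out cannot separate, even though the entering group has more heavy atoms and carries fluorine instead of chlorine. No supporting data bear on why this is so.

Steps involving compound 2 cannot be read, so the single pair of compound 1 and compound 3 is all that speaks to the series. As far as these compounds go, whether a different group on this oxygen-linked phenyl ring, such as an amine or a carboxylic acid in place of the trifluoromethyl group, would give a step beyond the scatter remains open.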